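A trifluoromethyl group on a fluorinated ring

This account rests on a few compounds, and the source may have more. Where it says the series, first, only, none or still open, it means among the compounds named here.

Compound 1 `CC1=C(/C=C/C(=O)/C=C/c2ccccc2)C(C)(C)CCC1O` is the simplest of the set. In a functional assay on LNCaP cells (Homo sapiens) for cytotoxicity, read by MTT assay, with a stated time of 72 h (on this read-out higher numbers stand for weaker inhibition and lower numbers for stronger inhibition), compound 1 gives 5800 nM. Compound 2 `CC1=C(/C=C/C(=O)/C=C/c2ccc(C(F)(F)F)cc2)C(C)(C)CCC1O` carries trifluoromethyl in place of hydrogen on an aromatic carbon; in this assay compound 2 gives 3000 nM, and the step is a 1.9-fold lower number from compound 1 to compound 2 (0.29 log units; within the scatter). Compound 3 `CC1=C(/C=C/C(=O)/C=C/c2ccccc2F)C(C)(C)CCC1O` differs from compound 1 by fluoro in place of hydrogen on an aromatic carbon; in this assay compound 3 gives 2900 nM, a step of a 2.0-fold lower number from compound 1 to compound 3 (0.30 log units; within the scatter). The values of compound 2 and compound 3 sit close to each other.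

Compound 4 `CC1=C(/C=C/C(=O)/C=C/c2cccc(C(F)(F)F)c2F)C(C)(C)CCC1O` has not yet been measured. Among the measured compounds shown here, it differs from compound 3 by trifluoromethyl in place of hydrogen on an aromatic carbon, the same kind of change as the one from compound 1 to compound 2, but the place is not the same: in compound 2 the new group stands para to a large group, whereas in compound 4 it stands ortho to a fluoro group and meta to a large group. Given that a 1.9-fold lower number from compound 1 to compound 2 (0.29 log units; within the scatter) lies within the scatter, a step of about a 1.5-fold lower number from compound 3 to compound 4 (0.16 log units; within the scatter) is expected. Compound 4 is therefore estimated at 2000 nM in this assay, with a range from 900 nM to 5000 nM.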

Compound 4, half-maximal inhibitory concentration: 1100 nM
Compound 4: the middle estimate sits 1.8-fold (0.26 log units) above what was measured; low and high end bracket the measured number.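

Putting trifluoromethyl in place of hydrogen on an aromatic carbon of compound 3 gives, in this assay, a 2.6-fold lower number from compound 3 to compound 4 (0.42 log units; beyond the scatter), a modest step that lies beyond the usual scatter. Both steps with this change run toward lower numbers, and they do not differ by more than the scatter, so the change carries over from one core to the other without a detectable difference in size: the same change on two cores in this assay, a 1.9-fold lower number (0.29 log units; within the scatter) from compound 1 to compound 2 and a 2.6-fold lower number (0.42 log units; beyond the scatter) from compound 3 to compound 4, 1.4-fold (0.13 log units) apart, within the scatter of two such steps Two pairs make no rule, however, and the group stands in a different place in compound 2 than in compound 4, where it is ortho to a fluoro group and meta to a large group, so these data cannot separate a change of core from a change of place.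

From the compounds shown here alone, it remains open how trifluoromethyl would behave in the place it holds in compound 4 with no fluoro group on the ring. Also open, going by these compounds, is whether an amine, a carboxylic acid or a longer alkyl chain at that position would move the number in the same direction.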